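Cytotoxicity of terpenoid triazoles on human kidney cells

The source may hold more compounds than are shown below. What is called first, only, known or untested is meant among the compounds shown, and "the series" means these compounds.

Measured so far:
- Compound 1 `C=C1CC[C@@H](C(C)C)[C@]12CC=C(C=O)CC2`: 550000 nM
- Compound 2 `C#CC1=CC[C@@]2(C)C(=C)CCC[C@]2(C)CC1`: 524000 nM
- Compound 3 `C=C1CCC[C@]2(C)CCC(c3cn(-c4ccc(C(C)=O)cc4)nn3)=CC[C@@]12C`: 520000 nM

The three compounds were tested in an ADME assay on HEK293 cells (Homo sapiens) for cytotoxicity, read by MTT assay, with a stated time of 48 h; a higher number here means a weaker inhibitor, a lower number a stronger inhibitor. In this assay compound 1 gives 550000 nM, compound 2 gives 524000 nM, and compound 3 gives 520000 nM. Compound 3 carries the lowest of the three numbers, but its nearest neighbour, compound 2, and its furthest, compound 1, both sit within the scatter of it, so the three compounds cannot be told apart on these numbers. All three are very weak inhibitors of cell viability.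

Compound 4 `C=C1CCC[C@]2(C)CCC(c3cn(-c4ccc(Cl)cc4)nn3)=CC[C@@]12C` has not yet been measured in this assay. It differs from compound 3 in one place: chloro in place of acetyl on an aromatic carbon. The shared core and the triazole-bearing phenyl ring are unchanged.

Going by the values given here, no pair of measured compounds differing in a single place is available, so no step of this kind can be read from the data. Compound 3 gives 520000 nM, and compound 1 and compound 2, which have quite different structures, give numbers within the scatter of it. Because compound 3 gives 520000 nM and the two other compounds do not move away from it, a change of one group on the phenyl ring is expected to leave the number within the usual scatter. For compound 4 the expected result is 520000 nM, with a range from 260000 nM to 1040000 nM. The estimated step of no change at the digits printed from compound 3 to compound 4 (within the scatter) is thus expected to be no larger than the scatter, in no particular direction.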

Compound 4, half-maximal inhibitory concentration: 609000 nM
Beside the measured number, compound 4's estimate is 1.2-fold (0.07 log units) below it; measured number inside the range.
By their numbers in this assay, from the lowest: compounds 3, 2, 1 and 4 (each within the scatter of the next).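

Going by these compounds alone, this is the first pair of measured compounds that differ in only one place, so the position can now be read directly rather than inferred from unrelated structures. In this assay, replacing acetyl with chloro on the aromatic carbon para to a large group gives a 1.2-fold higher number from compound 3 to compound 4 (0.07 log units; within the scatter), a step within the scatter, so the two compounds cannot be told apart even though the change removes a hydrogen-bond acceptor and a double bond outside the aromatic rings and brings in a chlorine atom. No measurement shown explains this lack of a clear difference.

Within the data shown here, this single pair tests only two groups at one place on the phenyl ring, so it cannot show whether this position would tolerate every substituent equally. On these data alone, an amine, a carboxylic acid or a longer chain at the same place could still move the number beyond the scatter, and the effect of any group at another carbon of the ring remains unknown.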